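The source may hold more compounds than are shown below. What is called first, only, known or untested is meant among the compounds shown, and "the series" means these compounds.

Measured so far in a functional assay on MV4-11 cells (Homo sapiens) for antiproliferative activity, read by CellTiter-Glo, with a stated time of 72 h; a lower number here means a stronger inhibitor of growth, a higher number a weaker inhibitor of growth:
- compound 1 `COCCN[C@H]1CC[C@H](Nc2cc(-c3csc(NCC4CCOCC4)n3)c(Cl)cn2)CC1`: 170 nM
- compound 2 `COCCN[C@H]1CC[C@H](Nc2cc(-c3csc(NCC4CCOCC4)n3)ccn2)CC1`: 910 nM

Compound 2 has the higher number of the two, at 910 nM, which makes it the weaker inhibitor of growth in this assay. The next compound, compound 3 `COCCN[C@H]1CC[C@H](Nc2cc(-c3csc(NCC4CCOCC4)n3)c(C)cn2)CC1`, keeps all of compound 2 except for one change: methyl in place of hydrogen on an aromatic carbon. In words, this is methyl in place of hydrogen on an aromatic carbon, the same carbon that carries chloro in compound 1.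

Among the compounds with values here, only one measured step bears on this change: a 5.4-fold higher number from compound 1 to compound 2 (0.73 log units; beyond the scatter). That step is beyond the scatter and shows that the compound with hydrogen at this carbon has the higher number. Methyl is a different group from chloro, however, and no compound with methyl here has been measured, so this single step is only a rough guide. A move to a lower number is expected, probably smaller than the step between the chloro and hydrogen compounds. The expected step is a 2.8-fold lower number from compound 2 to compound 3 (0.45 log units; beyond the scatter). The estimate for compound 3 is 320 nM, with an expected range of 130 nM to 750 nM.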

Compound 3, concentration for 50% growth inhibition: 1620 nM
For compound 3 the middle estimate is 5.1-fold (0.70 log units) below the measured one; the whole stated range lies below it.
By their numbers in this assay, from the lowest: compound 1; then compounds 2 and 3 (each within the scatter of the next).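

In this assay putting methyl on this carbon gives a 1.8-fold higher number from compound 2 to compound 3 (0.25 log units; within the scatter) and so cannot be told apart from leaving hydrogen there. Swapping chloro for methyl at the same carbon gives a 9.5-fold higher number from compound 1 to compound 3 (0.98 log units; beyond the scatter) and shows that the result at this position depends on which group is present, since simply replacing hydrogen with another group does not reproduce what chloro does in these compounds. The data offer no measurement that explains why chloro stands apart from methyl and hydrogen here.

The three compounds leave open how other groups on this carbon would compare, such as fluoro, bromo, trifluoromethyl, nitrile or methoxy, and so whether chloro is an isolated case or part of a wider trend among such groups. They also leave open whether the advantage of chloro would persist if the methoxyethyl amine chain or another part of the shared core were replaced, for example with a longer chain or a carboxylic acid.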